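Difluoromethoxy in place of trifluoromethyl

A few compounds are considered here, and "the series" means these few. Any claim that something is new, unique, unknown or untested is made for them only; others in the source may bear on it.

Measured so far in an ADME assay on microsomes from liver (Rattus norvegicus) for metabolic stability, with a stated time of 10 min; on this read-out lower numbers stand for a less stable compound and higher numbers for a more stable compound:
Compound 1 `FC(F)(F)c1ccccc1-c1ccc2[nH]c(C3=NCC4(CCCCC4)O3)nc2c1`: 32%
Compound 2 `FC(F)(F)c1ccccc1-c1ccc2[nH]c(C3=NCC4(CCCCC4)N3)nc2c1`: 91%
Compound 3 `FC(F)(F)c1ccccc1-c1ccc2[nH]c(C3=NOC4(CCCCC4)C3)nc2c1`: 75%

Of these three, compound 3 stands second highest, with compound 2 above it and compound 1 below it, both gaps beyond the usual scatter. Compound 4 `FC(F)Oc1ccccc1-c1ccc2[nH]c(C3=NOC4(CCCCC4)C3)nc2c1` has difluoromethoxy in place of trifluoromethyl on an aromatic carbon, ortho to a large group (difluoromethoxy in place of trifluoromethyl on an aromatic carbon). For the measured compounds named here, no measured pair shows this change, so the expectation starts from compound 3 at 75% and rests on the structural change alone. In this assay a small fall, not clearly beyond the scatter, is expected: a number 9 percentage points lower from compound 3 to compound 4 (within the scatter). For compound 4 the estimated value is 66%, with an expected range from 46% to 84%.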

Compound 4, percent of the compound remaining: 59%
Beside the measured number, compound 4's estimate is 7 percentage points above it; the measured number falls inside the stated range.
By their numbers in this assay, from the lowest: compound 1; then compound 4; then compound 3; then compound 2.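

On this position, ortho to a large group, this assay now has its first direct reading: difluoromethoxy in place of trifluoromethyl gives a number 16 percentage points lower from compound 3 to compound 4 (beyond the scatter) with the core unchanged. The step is modest but beyond the scatter, so this group is not a neutral exchange here, even though the heavy-atom count stays the same and one hydrogen-bond acceptor enters. No measurement at hand accounts for the fall.

On these data alone, whether the same change would give a step of similar size on the core of compound 2 stays open. So does what a methoxy group or a chlorine atom would give at this place.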